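The compounds below may be only part of what the source reports. "The series", "measured", "known", "first", "only" and "open" are said of these compounds alone.

Of the compounds shown here, two have been measured in an ADME assay on HEK-293T cells (Homo sapiens) for inhibition, read by MTT assay, with a stated time of 48 h; on this read-out higher numbers stand for weaker inhibition and lower numbers for stronger inhibition. Compound 1 `COc1ccc(-c2nc3cc(/C=C4\SC(=O)N(CC(=O)N5CCOCC5)C4=O)ccc3[nH]2)cc1OC` returns only a limit there, > 50000 nM. Among the measured compounds shown here, compound 2 `COc1cc(OC)c(-c2nc3cc(/C=C4\SC(=O)N(CC(=O)N5CCOCC5)C4=O)ccc3[nH]2)cc1OC` gives 35700 nM, the single number in the set. For the measured compounds named here, the step of an at least 1.4-fold lower number from compound 1 to compound 2 (0.14 log units; that floor lies within the scatter) is the only measured step; since compound 1 sits at the limit of > 50000 nM in this assay, at which 1 of the 2 values shown sits, just a floor for that step can be stated. Compound 3 `COc1cc(OC)c(-c2nc3cc(/C=C4\SC(=O)N(Cc5cccc(C)c5)C4=O)ccc3[nH]2)cc1OC` differs from compound 2 by 3-methylphenyl in place of (morpholin-4-yl)carbonyl on a saturated chain carbon bound to an amide-type nitrogen in a ring. Going by the values given here, no measured step touches that position: the one known step alters a methoxy on an aromatic carbon and leaves the substituent on the amide-type nitrogen unchanged, so it offers no guide to direction or size here. With nothing pointing either way, the expectation for compound 3 is a value near that of compound 2, with a wide range. Compound 3 is therefore estimated at 30000 nM, between 8000 nM and 100000 nM. The expected step this estimate implies is a 1.2-fold lower number from compound 2 to compound 3 (0.08 log units; within the scatter), a change that is expected to stay within the scatter.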

Compound 3, half-maximal inhibitory concentration: 3350 nM
For compound 3 the middle estimate is 9.0-fold (0.95 log units) above the measured one; measured number outside the range, below it.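

In this assay, the substituent on the saturated chain carbon bound to an amide-type nitrogen in a ring moves the read-out: 3-methylphenyl in place of (morpholin-4-yl)carbonyl gives an 11-fold lower number from compound 2 to compound 3 (1.03 log units; beyond the scatter). Unlike the earlier methoxy step, which has only a floor, this step has a number at both ends and lies beyond the scatter. It exchanges a whole group, from a non-aromatic ring with hetero atoms and a carbonyl to an all-carbon aromatic ring, and nothing measured in the set gives a cause for the step.

Open, from the compounds shown here alone, is which part of the exchange carries the step, since an unsubstituted benzyl or a chain ending in a carboxylic acid at this position would test the methyl and the aromatic ring separately. Also open, going by these compounds, is whether the methoxy step from compound 1 to compound 2 holds with 3-methylbenzyl in place.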